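Aryl substituent changes on the amide series, compound 3 to 4

This account rests on a few compounds, and the source may have more. Where it says the series, first, only, none or still open, it means among the compounds named here.

Of the compounds shown here, three of one series have been measured in an assay (Canis lupus familiaris) for binding affinity to platelet-activating factor receptor (Homo sapiens), read by radioligand binding; on this read-out higher numbers stand for weaker inhibition and lower numbers for stronger inhibition. Compound 1 `COc1cccc(-c2ccc(C(=O)NCCCCc3cccnc3)cc2)c1` gives 280 nM, compound 2 `Cc1cccc(-c2ccc(C(=O)NCCCCc3cccnc3)cc2)c1` gives 500 nM, and compound 3 `O=C(NCCCCc1cccnc1)c1ccc(-c2cccc(O)c2)cc1` gives 300 nM. The steps among them are all small: a 1.8-fold higher number from compound 1 to compound 2 (0.25 log units; within the scatter), a 1.1-fold higher number from compound 1 to compound 3 (0.03 log units; within the scatter), and a 1.7-fold lower number from compound 2 to compound 3 (0.22 log units; within the scatter). Compound 3 therefore sits among the others, its number close to that of compound 1 and separated from compound 2 by no more than the scatter.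

Compound 4 `Cc1ccc(-c2ccc(C(=O)NCCCCc3cccnc3)cc2)cc1C` is not yet measured. It differs from compound 3 by 3,4-dimethylphenyl in place of 3-hydroxyphenyl on an aromatic carbon. Among the measured compounds shown here, the step that bears most directly on this change is the one from compound 2 to compound 3, in which hydroxy replaced methyl and the number moved by a 1.7-fold lower number from compound 2 to compound 3 (0.22 log units; within the scatter); compound 4 carries methyl again, with a second methyl added. The methyl-for-methoxy step, a 1.8-fold higher number from compound 1 to compound 2 (0.25 log units; within the scatter), is of the same small size. No change beyond the scatter is expected in this assay, and the step from compound 3 to compound 4 is estimated at a 1.5-fold higher number from compound 3 to compound 4 (0.18 log units; within the scatter). Compound 4 is expected to give 450 nM, with a range from 200 nM to 1100 nM.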

Compound 4, half-maximal inhibitory concentration: 200 nM
Compound 4: the middle estimate sits 2.3-fold (0.35 log units) above what was measured; low and high end bracket the measured number.
By their numbers in this assay, from the lowest: compounds 4, 1, 3 and 2 (each within the scatter of the next, the first and the last beyond it).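

In this assay, among the compounds shown here, the second methyl of the 3,4-dimethylphenyl group gives a 2.5-fold lower number from compound 2 to compound 4 (0.40 log units; beyond the scatter) and is the first single change to exceed the scatter. The comparisons with the oxygen-bearing aryl groups, a 1.5-fold lower number from compound 3 to compound 4 (0.18 log units; within the scatter) and a 1.4-fold lower number from compound 1 to compound 4 (0.15 log units; within the scatter), stay within the scatter, so an aryl group carrying only carbon substituents cannot be told apart from the 3-hydroxyphenyl or 3-methoxyphenyl groups here. No supporting measurement accounts for the step from the added methyl.

Still open, as far as these compounds go, is whether chlorine, trifluoromethyl or ethyl in place of the added methyl would give a step of similar size. From the compounds shown here alone, it is also open whether the step from the added methyl carries over to analogues with a longer chain on the amide nitrogen.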